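The source may report more compounds than this note shows. Statements on the series, on what has been measured and on what is new or still open speak of the compounds shown alone.

Compound 1, `CCC/C(=C\C=C\C(=O)N[C@H](C)CCCc1cccnc1)c1ccc(OC)cc1`, was tested in a functional assay with platelet-activating factor receptor (Cavia porcellus) as the target (on this read-out lower numbers stand for an effect already at smaller amounts and higher numbers for an effect only at larger amounts of compound), where compound 1 gives 0.52 mg/kg. Among the three compounds measured so far, compound 1 has the second highest number. Compound 3, `CCCCC/C(=C/C=C/C(=O)N[C@H](C)CCCc1cccnc1)c1ccc(OC)cc1`, gives 0.78 mg/kg, a number within the scatter of compound 1. Compound 2, `COc1ccc(C(=C/C=C/C(=O)Nc2ccc(-c3cccnc3)cc2)c2ccc(OC)cc2)cc1`, gives 0.15 mg/kg, a lower number that lies beyond the scatter. The unmeasured compound 4, `COc1ccc(/C(=C/C=C/C(=O)N[C@H](C)CCCc2cccnc2)C2CCCCC2)cc1`, differs from compound 1 in a single place: cyclohexyl in place of propyl on a double-bonded chain carbon bound to an aromatic carbon and a double-bonded chain carbon Because compound 3 gives 0.78 mg/kg and so sits close to compound 1, a change at this chain carbon is expected to move the number by no more than the usual scatter. Compound 4 is therefore estimated at 0.5 mg/kg, with a range from 0.2 mg/kg to 1.3 mg/kg. The expected step of a 1.0-fold lower number from compound 1 to compound 4 (0.02 log units; within the scatter) is thus small, with no clear direction.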

Compound 4, dose for 50% inhibition: 0.21 mg/kg
The estimate for compound 4 lay 2.4-fold (0.38 log units) above the measured number; low and high end bracket the measured number.
By their numbers in this assay, from the lowest: compounds 2 and 4 (each within the scatter of the next); then compounds 1 and 3 (each within the scatter of the next).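

In this assay the change from propyl to cyclohexyl on this chain carbon gives a 2.5-fold lower number from compound 1 to compound 4 (0.39 log units; beyond the scatter) and so shows that the position accepts a six-membered non-aromatic ring of carbon only. The step is modest, but it shows that a change at this carbon can move the number beyond the scatter. Nothing available explains why the number falls with this change. Still open, on these data alone, is whether a smaller ring such as cyclopropyl, or a ring holding nitrogen such as piperidinyl, would give a similar number at this chain carbon.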